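Amine to hydroxymethyl swap: compound 2 to compound 3

The source may report more compounds than this note shows. Statements on the series, on what has been measured and on what is new or still open speak of the compounds shown alone.

Measured compounds:
compound 1 `COc1ccc(CNCc2c(OC)cc(Oc3cccc(Nc4ccccc4)c3)cc2OC)cc1`: 1890 nM
compound 2 `COc1cc(Oc2cccc(Nc3ccccc3)c2)cc(OC)c1CN(C)C`: only a limit, given below

In a functional assay on HT-29 cells (Homo sapiens) for inhibition, read by MTT assay, with a stated time of 72 h (a higher number here means a weaker inhibitor, a lower number a stronger inhibitor), compound 1 gives 1890 nM. For compound 2 the assay reports only a limit, > 20000 nM, which is the limit of > 20000 nM in this assay, at which 1 of the 2 values shown sits. Compound 3 `COc1cc(Oc2cccc(Nc3ccccc3)c2)cc(OC)c1CCO` differs from compound 2 by hydroxymethyl in place of dimethylamino on a saturated chain carbon bound to an aromatic carbon. Going by the values given here, the one measured step at this position, an at least 10-fold higher number from compound 1 to compound 2 (1.02 log units; beyond the scatter), concerned a different pair of groups and tells nothing about a hydroxymethyl; compound 2 itself stands only at a limit. Compound 3 is therefore expected to stay near that limit, with a number no higher from compound 2 to compound 3 (the limit leaves the size open) as the expected step. The estimate for compound 3 is 20000 nM, with a range of 5000 nM to 60000 nM.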

Compound 3, half-maximal inhibitory concentration: 13900 nM
Beside the measured number, compound 3's estimate is 1.4-fold (0.16 log units) above it; measured number inside the range.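

In this assay, hydroxymethyl at this position gives a measured number where dimethylamino gave only a limit, with an at least 1.4-fold lower number from compound 2 to compound 3 (0.15 log units; that floor lies within the scatter), so no gain is established. Set against (4-methoxybenzyl)amino, hydroxymethyl shows a 7.4-fold higher number from compound 1 to compound 3 (0.87 log units; beyond the scatter), and compound 1 remains the strongest of the three. The first step is only a floor because compound 2 stands at a limit: the limit of > 20000 nM in this assay, at which 1 of the 3 values shown sits.

Open, on these data alone, is whether the benzyl part or the amine nitrogen of (4-methoxybenzyl)amino carries the difference. An unsubstituted benzylamino group or a primary amine at this place would separate the two.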